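The compounds below may be only part of what the source reports. "The series", "measured", "known", "first", "only" and "open" are said of these compounds alone.

Compound 1 `O=C(/C=C/c1ccc(OCc2cn(Cc3ccccc3)nn2)cc1)c1ccc(Br)cc1` gives 34% in a functional assay on A549 cells (Homo sapiens) for inhibition, read by MTT assay, with a stated time of 48 h, tested at 10 uM (on this read-out lower numbers stand for less inhibition of growth and higher numbers for more inhibition of growth at the one concentration tested), the lowest of the two numbers; its nearest neighbour, compound 2 `O=C(/C=C/c1ccc(OCc2cn(Cc3ccc(F)cc3)nn2)cc1)c1ccc(Br)cc1`, gives 43% in this assay. Compound 3 `COc1ccc(C(=O)/C=C/c2ccc(OCc3cn(Cc4ccccc4)nn3)cc2)cc1` differs from compound 1 by methoxy in place of bromo on an aromatic carbon. Among the compounds with values here, no measured step touches this position: the only measured step, a number 9 percentage points higher from compound 1 to compound 2 (within the scatter), concerns a different ring and is within the scatter. The expected step is therefore a number 1 percentage points higher from compound 1 to compound 3 (within the scatter), with no change beyond the scatter foreseen. Compound 3 is estimated at 35% in this assay, between 15% and 55%.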

Compound 3, percent growth inhibition at one concentration: 44%
Compound 3: the middle estimate sits 9 percentage points below what was measured; low and high end bracket the measured number.
By their numbers in this assay, from the lowest: compounds 1, 2 and 3 (each within the scatter of the next).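

With methoxy in place of bromo on this aromatic carbon, the result is a number 10 percentage points higher from compound 1 to compound 3 (within the scatter) in this assay. Within the data shown here, this gives the first reading at this position: 4-bromophenyl and 4-methoxyphenyl are not told apart here, although the entering group counts one hydrogen-bond acceptor and the leaving group none. No measurement given here bears on the reason for this result.

On these data alone, whether an amine or a carboxylic acid at this place would give a step beyond the scatter remains open. So does whether methoxy would read the same alongside the fluoro of compound 2.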